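A few compounds are considered here, and "the series" means these few. Any claim that something is new, unique, unknown or untested is made for them only; others in the source may bear on it.

Compound 1, `NCc1cc(Oc2cccc(C(=O)N3CC[C@@H](N)C3)c2)nc(C(F)(F)F)c1`: 670 nM
Compound 2, `NCc1cc(O[C@H]2CCCN(C(=O)Nc3ccccc3)C2)nc(C(F)(F)F)c1`: 1900 nM

Of the compounds shown here, two have so far been measured in an ADME assay on the whole organism (plasma, Mus musculus) for pharmacokinetics, read by LC-MS, at a dose of 30 mg/kg by the oral route; a higher number here means more compound in the circulation at the dose given, a lower number less compound in the circulation. Compound 1 gives 670 nM, the lower of the two numbers. Among the compounds with values here, its only neighbour is compound 2 with 1900 nM, and the gap between the two lies beyond the scatter of this assay, so compound 1 stands at the bottom of what has been seen. The two compounds differ in several places at once, so nothing can be taken from their pair about any single change.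

The next compound is compound 3, `NCc1cc(Oc2cccc(C(=O)NC[C@@H](O)CO)c2)nc(C(F)(F)F)c1`. It keeps the core of compound 1 and differs from it in one place: (2,3-dihydroxypropyl)amino in place of 3-aminopyrrolidin-1-yl on a carbonyl carbon. Within the data shown here, no measured pair shows what such a change does in this assay, and the amide carbonyl and everything else stay as in compound 1. The step from compound 1 to compound 3 is therefore expected to be small, a 1.2-fold higher number from compound 1 to compound 3 (0.08 log units; within the scatter), and not to pass beyond the scatter in either direction. For compound 3 the estimate is 800 nM, with a likely range from 250 nM to 2500 nM.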

Compound 3, maximal plasma concentration: 2770 nM
Compound 3: middle estimate off by 3.5-fold (0.54 log units), on the low side, outside the stated range (above it).
By their numbers in this assay, from the lowest: compound 1; then compounds 2 and 3 (each within the scatter of the next).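

In this assay the group on the carbonyl carbon proves to be a place where the number can move: (2,3-dihydroxypropyl)amino in place of 3-aminopyrrolidin-1-yl gives a 4.1-fold higher number from compound 1 to compound 3 (0.62 log units; beyond the scatter) while the rest of the core of compound 1 stays the same. Within the data shown here, this is the first single change, and it shows that the 3-aminopyrrolidin-1-yl group can be given up without any loss in the maximal plasma concentration at this dose. The swap keeps the count of 6 heavy atoms but gives up the five-membered ring and a nitrogen, and it goes from 1 hydrogen-bond donor to 3 hydrogen-bond donors, and nothing on hand explains the higher number.

Since the ring, the amine and the hydroxyl groups all change in one step, the compounds shown leave open which of them carries the difference; an open chain ending in an amine, or a shorter chain with a single hydroxyl, would separate these. Also open, going by these compounds, are the other stereocentre of the diol chain and whether the same group would do the same on the core of compound 2.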